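Swapping a small fluorinated group for a long chlorinated chain

This account rests on a few compounds, and the source may have more. Where it says the series, first, only, none or still open, it means among the compounds named here.

Compound 2, `O=C(Nc1cccnc1)c1ccccc1OCc1ccccc1C(F)(F)F`, was tested in an assay on lysate for inhibition of phosphatidylcholine:ceramide cholinephosphotransferase 2 (Homo sapiens), read by HPLC, with stated times of 30 min and 2 h (a lower number here means a stronger inhibitor, a higher number a weaker inhibitor), where compound 2 gives 2100 nM. For the measured compounds named here, the only other measured compound is compound 1, `O=C(Nc1cccnc1)c1ccccc1OCc1ccccc1F`, which differs from compound 2 only in carrying fluoro where compound 2 carries trifluoromethyl; in this assay compound 1 gives 3500 nM. Going by the values given here, the one measured step, a 1.7-fold lower number from compound 1 to compound 2 (0.22 log units; within the scatter), shows that these two values are not distinguishable from each other.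

Compound 3, `O=C(Nc1cccnc1)c1ccccc1OCc1ccccc1OCCCCCCCl`, has not been measured. It differs from compound 2 in one place: (6-chlorohexyl)oxy in place of trifluoromethyl on an aromatic carbon. Among the compounds with values here, the single measured step swapped one small group for another at that same aromatic carbon and stayed within the scatter. The change to compound 3 is much larger, bringing in a long chain with an oxygen and a chlorine, so that step offers little guidance on direction or size. With so little to go on, the expectation is only a modest shift, a 1.2-fold lower number from compound 2 to compound 3 (0.07 log units; within the scatter), with wide uncertainty.

For compound 3 in this assay, the estimated value is 1800 nM, expected to lie between 500 nM and 7000 nM.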

Compound 3, half-maximal inhibitory concentration: 470 nM
The estimate for compound 3 lay 3.8-fold (0.58 log units) above the measured number, outside the stated range (below it).
By their numbers in this assay, from the lowest: compound 3; then compounds 2 and 1 (each within the scatter of the next).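

In this assay, this aromatic carbon had so far shown no separation between fluoro and trifluoromethyl, yet a long chain does separate: (6-chlorohexyl)oxy gives a 4.5-fold lower number from compound 2 to compound 3 (0.65 log units; beyond the scatter) when it replaces trifluoromethyl and a 7.4-fold lower number from compound 1 to compound 3 (0.87 log units; beyond the scatter) when it replaces fluoro. The position therefore accepts a much larger group than either small one, and the number falls rather than rises, which leaves compound 3 the strongest inhibitor of the three. Whether the length of the chain, its oxygen or its chlorine accounts for the drop is not settled by anything available here.

Compound 3 brings in the length, the oxygen and the chlorine all at once, so the compounds shown cannot weigh any of these alone. From the compounds shown here alone, a plain hexyl chain, a hexyloxy chain without the chlorine, a shorter or longer chain, or an amine or a carboxylic acid in place of the chlorine would each help pull those parts apart, and whether such a chain has the same effect elsewhere on this ring also stays open.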